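A few compounds are considered here, and "the series" means these few. Any claim that something is new, unique, unknown or untested is made for them only; others in the source may bear on it.

Working notes on the series. Compound 1 `COc1cc(/C=C/C(=O)/C=C/c2cc(OC)c(OC)c(OC)c2)ccc1OCc1cn(CCOc2cc(=O)oc3ccccc23)nn1` and compound 2 `COc1cc(/C=C/C(=O)/C=C/c2ccccc2)ccc1OCc1cn(CCOc2cc(=O)oc3ccccc23)nn1` share one core, and in a functional assay on PC-3 cells (Homo sapiens) for inhibition, read by sulforhodamine B assay, with a stated time of 48 h, tested at 50 uM (on this read-out lower numbers stand for less inhibition of growth and higher numbers for more inhibition of growth at the one concentration tested), compound 1 gives 22% while compound 2 gives 10%. The change between them is 3,4,5-trimethoxyphenyl in place of phenyl on a double-bonded chain carbon bound to a double-bonded chain carbon, and the step it made is a number 12 percentage points higher from compound 2 to compound 1 (beyond the scatter).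

Compound 3 `COc1cc(/C=C/C(=O)/C=C/c2ccccc2)ccc1OCc1cn(CCCOc2cc(=O)oc3ccccc23)nn1` carries a different core; how that core differs from the core of compound 2 is not broken down here. In this assay compound 3 is reported as "not active" (no number reported), so no single number stands for it.

Compound 4 `COc1cc(/C=C/C(=O)/C=C/c2cc(OC)c(OC)c(OC)c2)ccc1OCc1cn(CCCOc2cc(=O)oc3ccccc23)nn1` has not yet been tested. It differs from compound 3 by 3,4,5-trimethoxyphenyl in place of phenyl on a double-bonded chain carbon bound to a double-bonded chain carbon, the same change that was made from compound 2 to compound 1, at the same place on the chain; among the compounds shown this change occurs two times in all. Because the step of a number 12 percentage points higher from compound 2 to compound 1 (beyond the scatter) was modest but beyond the scatter, a step of about the same size is expected from compound 3 to compound 4 in this assay, resting on that one measured pair and on the report that compound 3 shows no activity. Compound 4 is therefore estimated at 12%, with a range from 0% to 28%.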

Compound 4, percent growth inhibition at one concentration: 12%
Compound 4: middle estimate and measured number agree at the digits printed, and the stated range covers the measured number.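

For the compounds shown here, compound 3 has no number in this assay, so no step from compound 3 to compound 4 can be read. The compounds shown leave open whether 3,4,5-trimethoxyphenyl in place of phenyl has the same size of effect on both cores. Nothing shown here bears on the cause of these results.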